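A few compounds are considered here, and "the series" means these few. Any claim that something is new, unique, unknown or untested is made for them only; others in the source may bear on it.

Among the compounds with values here, in a functional assay on HEK293 cells for positive allosteric modulation of metabotropic glutamate receptor 5 (Homo sapiens), read by calcium flux (on this read-out lower numbers stand for smaller maximal responses and higher numbers for larger maximal responses), compound 2 `Cc1ccc(N2CCn3nc(COc4ccccc4)cc3C2=O)cc1` gives 65%, the lower of the two numbers measured so far; compound 1 `O=C1c2cc(COc3ccccc3)nn2CCN1c1cccc(F)c1` gives 81%. Compound 3 `O=C1c2cc(COc3ccccc3)nn2CCN1c1ccc(F)cn1` differs from compound 2 by 5-fluoropyridin-2-yl in place of 4-methylphenyl on an amide-type nitrogen in a ring. Within the data shown here, the only measured step, a number 16 percentage points lower from compound 1 to compound 2 (beyond the scatter), swaps one group for another at the same ring nitrogen, so it bears on this change only loosely, and no measured step brings in a ring with a hetero atom. Because compound 1, which also carries a fluorine on this ring, reached 81%, compound 3 is expected to move by a number 10 percentage points higher from compound 2 to compound 3 (within the scatter). Compound 3 is thus estimated at 75%, within 55% to 95%.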

Compound 3, largest response reached (Emax), in percent of the reference or control that the assay uses: 72%
Estimate against measurement, compound 3: 3 percentage points above, and the stated range covers the measured number.
By their numbers in this assay, from the lowest: compounds 2, 3 and 1 (each within the scatter of the next, the first and the last beyond it).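

Placing 5-fluoropyridin-2-yl on the amide-type nitrogen in place of 4-methylphenyl gives a number 7 percentage points higher from compound 2 to compound 3 (within the scatter) and in place of 3-fluorophenyl gives a number 9 percentage points lower from compound 1 to compound 3 (within the scatter) so this position accepts an aromatic ring with a hetero atom. Compound 3 cannot be told apart from either neighbour, even though compound 1 and compound 2 differ beyond the scatter. Nothing available explains these numbers. From the compounds shown here alone, it remains open whether the fluorine or the ring nitrogen matters more, which a plain pyridin-2-yl group would help to separate. Going by these compounds, how an amine or a carboxylic acid on this ring would behave also remains unknown.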